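This account rests on a few compounds, and the source may have more. Where it says the series, first, only, none or still open, it means among the compounds named here.

Compound 1, `C=CCN(C)C(=O)c1ccc(C(CC)(CC)c2ccc(OCCC(O)(CC)CC)c(C)c2)n1CC`, gives in an assay on cells for agonist activity at vitamin D3 receptor (Homo sapiens), with a stated time of 96 h (a lower number here means that less compound is needed, a higher number that more compound is needed for the effect), only a limit of the assay, > 10000 nM.
Compound 2, `CCOC(=O)C(CC(=O)OC)NC(=O)c1ccc(C(CC)(CC)c2ccc(OCCC(O)(CC)CC)c(C)c2)n1CC`, gives in this assay 21 nM.

For the measured compounds named here, compound 2 thus holds the only true number in this assay; the other entry is a limit (the limit of > 10000 nM in this assay, at which 1 of the 2 values shown sits). Compound 3, `CCn1c(C(=O)N(C)CCO)ccc1C(CC)(CC)c1ccc(OCCC(O)(CC)CC)c(C)c1`, differs from compound 2 at one place: a group of 5 heavy atoms (3 carbon, 1 nitrogen, 1 oxygen; no ring) in place of a group of 12 heavy atoms (7 carbon, 1 nitrogen, 4 oxygen; no ring), on a carbonyl carbon. Going by the values given here, the one measured step that bears on this change is an at least 470-fold lower number from compound 1 to compound 2 (2.67 log units; beyond the scatter), where the larger group on the carbonyl carbon went with a far lower number than a small group of similar size to the one entering compound 3. Reversing that size of group is therefore expected to raise the number substantially, with a 140-fold higher number from compound 2 to compound 3 (2.15 log units; beyond the scatter) as the estimated step, though the hydroxyl of the entering group has no counterpart in compound 1. Compound 3 is expected to give about 3000 nM, with a range from 300 nM to 30000 nM.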

Compound 3, half-maximal effective concentration: 52.7 nM
Estimate against measurement, compound 3: 57-fold (1.76 log units) above; measured number outside the range, below it.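

In this assay, the number of heavy atoms on the carbonyl carbon does not decide the outcome: the much smaller (2-hydroxyethyl)(methyl)amino group gives only a 2.5-fold higher number from compound 2 to compound 3 (0.40 log units; beyond the scatter). Compound 1 and compound 3 carry groups of equal heavy-atom count, and hydroxymethyl in place of vinyl on a saturated chain carbon bound to an amide-type nitrogen gives an at least 180-fold lower number from compound 1 to compound 3 (2.27 log units; beyond the scatter), so the large step seen earlier goes at least as much with this change at the chain as with group size. The true size of that step stays unknown, as compound 1 gives only a limit: the limit of > 10000 nM in this assay, at which 1 of the 3 values shown sits.

On these data alone, whether the hydroxyl itself matters or only the loss of the vinyl stays open, and a propyl chain or a methoxyethyl chain on that nitrogen would separate the two. Also open, as far as these compounds go, is how a carboxylic acid or a primary amine at the chain end would fare.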